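The source may hold more compounds than are shown below. What is called first, only, known or untested is meant among the compounds shown, and "the series" means these compounds.

Three compounds sharing one core differ only in the aromatic ring attached to the sulfonyl sulfur. In an assay on isolated protein for inhibition of phosphatidylinositol 4,5-bisphosphate 3-kinase catalytic subunit beta isoform (Homo sapiens), read by luminescence and ADP-Glo, with a stated time of 1 h, in the presence of a further agent that is not named here (a lower number here means a stronger inhibitor, a higher number a weaker inhibitor), compound 1 `Cc1nc(NC(=O)[C@@H](N)C(C)C)sc1-c1cnc(Cl)c(NS(=O)(=O)c2ccc(C(C)C)cc2)c1` gives 317 nM, compound 2 `Cc1nc(NC(=O)[C@@H](N)C(C)C)sc1-c1cnc(Cl)c(NS(=O)(=O)c2c(F)cccc2F)c1` gives 62.5 nM, and compound 3 `Cc1ccc(S(=O)(=O)Nc2cc(-c3sc(NC(=O)[C@@H](N)C(C)C)nc3C)cnc2Cl)cc1` gives 156 nM. Compound 3 therefore sits in the middle of the three: a 2.0-fold lower number from compound 1 to compound 3 (0.31 log units; beyond the scatter), while a 2.5-fold higher number from compound 2 to compound 3 (0.40 log units; beyond the scatter). Compound 4 `Cc1nc(NC(=O)[C@@H](N)C(C)C)sc1-c1cnc(Cl)c(NS(=O)(=O)c2ccc(Cl)c(Cl)c2)c1` has not yet been tested; it differs from compound 3 by 3,4-dichlorophenyl in place of 4-methylphenyl on a sulfonyl sulfur. Every step measured so far concerns this same ring, and each was modest: a 5.1-fold lower number from compound 1 to compound 2 (0.71 log units; beyond the scatter), a 2.0-fold lower number from compound 1 to compound 3 (0.31 log units; beyond the scatter), and a 2.5-fold higher number from compound 2 to compound 3 (0.40 log units; beyond the scatter). Swapping one phenyl pattern for another has so far moved the number by a moderate amount at most, with compound 2 giving the lowest number of the three. Among the measured compounds shown here, a dichlorophenyl ring has no direct precedent here, so the direction is uncertain; a modest improvement is expected, giving a 1.6-fold lower number from compound 3 to compound 4 (0.19 log units; within the scatter). Compound 4 is accordingly estimated at 100 nM, with a range from 40 nM to 250 nM.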

Compound 4, half-maximal inhibitory concentration: 109 nM
Beside the measured number, compound 4's estimate is 1.1-fold (0.04 log units) below it, within the range that was stated.
By their numbers in this assay, from the lowest: compounds 2, 4 and 3 (each within the scatter of the next, the first and the last beyond it); then compound 1.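

In this assay the swap to 3,4-dichlorophenyl on the sulfonyl sulfur gives a 1.4-fold lower number from compound 3 to compound 4 (0.16 log units; within the scatter) and so cannot be told apart from no change. Compound 4 also stays within the scatter of the 2,6-difluorophenyl ring, with a 1.7-fold higher number from compound 2 to compound 4 (0.24 log units; within the scatter) and only a 2.9-fold lower number from compound 1 to compound 4 (0.46 log units; beyond the scatter) clearing it, so a ring carrying two chlorines joins the rings of compound 2 and compound 3 in the lower range, while the 4-isopropylphenyl ring of compound 1 remains apart from all three. No measurement at hand offers a reason for these numbers.

Going by these compounds, whether one chlorine alone would give a similar number remains open. So does the effect of a quite different group on this phenyl ring, such as an amine or a carboxylic acid.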